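The source may report more compounds than this note shows. Statements on the series, on what has been measured and on what is new or still open speak of the compounds shown alone.

Two measured compounds share one core. Compound 1 `ClCc1ccccc1Cn1cnc2c(Cl)nc(Cl)nc21` carries two chloro groups on that core; compound 2 `ClCc1ccccc1Cn1cnc2ncnc(Cl)c21` carries one. In a functional assay on HCC 2998 cells (Homo sapiens) for cytotoxicity, read by sulforhodamine B assay, with a stated time of 48 h (a lower number here means a stronger inhibitor of growth, a higher number a weaker inhibitor of growth), compound 1 gives 3380 nM, and in this assay compound 2 gives 4260 nM. Going by the values given here, compound 1 holds the lower of the two numbers, but the gap to compound 2 lies within the scatter, so the two are indistinguishable on these data; no step between them is counted here.

Compound 3 `Nc1nc(Cl)c2ncn(Cc3ccccc3CCl)c2n1` is the next point. Relative to compound 1 the change is amino in place of chloro on an aromatic carbon. Among the compounds with values here, no pair of measured compounds shows the effect of an amino in place of a chloro at this position, so there is no counted step to lean on; the only anchor is the flat picture given by compound 1 and compound 2, which differ in a different place and sit within the scatter of each other.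

Given that, the step from compound 1 to compound 3 is expected to be small, in no firm direction, roughly a 1.0-fold higher number from compound 1 to compound 3 (0.02 log units; within the scatter). Compound 3 is estimated at 3500 nM in this assay, with a plausible range from 1000 nM to 12000 nM.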

Compound 3, concentration for total growth inhibition: 6610 nM
Beside the measured number, compound 3's estimate is 1.9-fold (0.28 log units) below it; low and high end bracket the measured number.
By their numbers in this assay, from the lowest: compounds 1, 2 and 3 (each within the scatter of the next).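

In this assay, the change to amino in place of chloro on an aromatic carbon, between two ring nitrogen atoms, gives a 2.0-fold higher number from compound 1 to compound 3 (0.29 log units; within the scatter). Going by these compounds alone, this is the first counted step at this position, and it shows that exchanging these two groups, which differ in their counts of hydrogen-bond donors and acceptors, does not carry the number beyond the scatter; compound 3 stays in the same range as compound 1 on these data, although the step lies close to the edge of the scatter and a single pair supports no trend. No measurement offered here bears on why the two groups read alike, so nothing can be said about the cause.

Still open, going by these compounds, is whether a larger group at this position, such as dimethylamino, methoxy or a longer amine chain, would give a step beyond the scatter, or whether this position accepts substitution broadly. Also open, on these data alone, is how the chloro group that compound 1 and compound 3 share, or the chloromethyl group on the benzyl ring, contributes, since neither is varied in a counted step.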